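The source may hold more compounds than are shown below. What is called first, only, known or untested is meant among the compounds shown, and "the series" means these compounds.

Compound 3 `CS(=O)(=O)c1ccc(-c2cnc3[nH]cc(-c4nnc(-c5ccc(Cl)cc5)o4)c(=O)c3c2)cc1` holds the lowest of the three numbers in a functional assay on HCT-116 cells (Homo sapiens) for inhibition, read by MTT assay, with a stated time of 24 h, tested at 2.5 uM (on this read-out lower numbers stand for less inhibition of growth and higher numbers for more inhibition of growth at the one concentration tested), where compound 3 gives 2.06%; compound 1 `N#Cc1ccc(-c2cnc3[nH]cc(-c4nnc(-c5ccc(F)cc5)o4)c(=O)c3c2)cc1` gives 10.2% and compound 2 `CS(=O)(=O)c1ccc(-c2cnc3[nH]cc(-c4nnc(-c5ccc(F)cc5)o4)c(=O)c3c2)cc1` gives 10.7%, and both of those sit within the usual scatter of the figure for compound 3. Compound 4 `N#Cc1ccc(-c2cnc3[nH]cc(-c4nnc(-c5ccc(Cl)cc5)o4)c(=O)c3c2)cc1` differs from compound 3 by cyano in place of methylsulfonyl on an aromatic carbon. The same exchange has been measured in the opposite direction: a number 0.5 percentage points higher from compound 1 to compound 2 (within the scatter). The other measured step, a number 8.6 percentage points lower from compound 2 to compound 3 (within the scatter), also stayed within the scatter. No step beyond the scatter is therefore expected in this assay for compound 4, in either direction, and a number 1.9 percentage points higher from compound 3 to compound 4 (within the scatter) is the expected outcome. Compound 4 is accordingly estimated at 4%, within a range from -3% to 12%.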

Compound 4, percent growth inhibition at one concentration: 13.7%
Estimate against measurement, compound 4: 9.7 percentage points below; measured number above the stated range.
By their numbers in this assay, from the lowest: compounds 3, 1, 2 and 4 (each within the scatter of the next, the first and the last beyond it).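

Among these compounds, on the chloro compounds, cyano in place of methylsulfonyl at this position gives a number 11.6 percentage points higher from compound 3 to compound 4 (beyond the scatter) in this assay and is the only step here beyond the scatter. That does not establish that the exchange depends on the halogen: the same change on two cores in this assay, a number 0.5 percentage points higher (within the scatter) from compound 1 to compound 2 and a number 11.6 percentage points lower (beyond the scatter) from compound 4 to compound 3, 12.1 percentage points apart, within the scatter of two such steps. Chloro in place of fluoro with cyano in place gives a number 3.5 percentage points higher from compound 1 to compound 4 (within the scatter) and adds no clear effect of the halogen either: the same change on two cores in this assay, a number 8.6 percentage points lower (within the scatter) from compound 2 to compound 3 and a number 3.5 percentage points higher (within the scatter) from compound 1 to compound 4, 12.1 percentage points apart, within the scatter of two such steps.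

From the compounds shown here alone, how an amine or a carboxylic acid on this aromatic carbon would read remains open. So does whether bromo in place of chloro would change the number.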